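The compounds below may be only part of what the source reports. "The series", "measured", "known", "first", "only" and "open" are said of these compounds alone.

Working notes on the series. Compound 1 `N#Cc1c(Nc2ccccc2F)nc(SCc2cn(Cc3ccccc3Cl)nn2)nc1-c1ccccc1` gives 8060 nM in a functional assay on MCF7 cells (Homo sapiens) for inhibition, read by MTT assay, with a stated time of 72 h; a lower number here means a stronger inhibitor, a higher number a weaker inhibitor. Compound 2 `Cc1ccc(Nc2nc(SCc3cn(Cc4ccccc4Cl)nn3)nc(-c3ccccc3)c2C#N)cc1` gives 9420 nM in this assay. Going by the values given here, the one recorded step, a 1.2-fold higher number from compound 1 to compound 2 (0.07 log units; within the scatter), exchanges 2-fluorophenyl for 4-methylphenyl on a nitrogen on an aromatic ring and leaves the two numbers within the scatter of each other. Among the compounds with values here, compound 2 thus holds the highest of the two numbers so far, with compound 1 its nearest neighbour, the gap within the scatter.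

Compound 3 `Cc1ccc(Nc2nc(SCc3cn(Cc4ccccc4Cl)nn3)nc(-c3ccc(C(C)C)cc3)c2C#N)cc1` differs from compound 2 by isopropyl in place of hydrogen on an aromatic carbon: hydrogen leaves and isopropyl enters on an aromatic carbon of a six-membered aromatic ring of carbon only, para to a large group; cut one bond further out, phenyl becomes 4-isopropylphenyl. Within the data shown here, no measured step touches this ring. Among the measured compounds shown here, the only step in hand sits on the nitrogen-linked aryl and says nothing about the carbon-linked one, so the direction is open and no step beyond the scatter is assumed. The expected step from compound 2 to compound 3 in this assay is a 1.0-fold lower number from compound 2 to compound 3 (0.02 log units; within the scatter), with wide uncertainty. Compound 3 is therefore estimated at 9000 nM in this assay, within 3000 nM to 27000 nM.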

Compound 3, half-maximal inhibitory concentration: 12200 nM
For compound 3 the middle estimate is 1.4-fold (0.13 log units) below the measured one; the measured number falls inside the stated range.
By their numbers in this assay, from the lowest: compounds 1, 2 and 3 (each within the scatter of the next).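

In this assay, going by these compounds alone, isopropyl in place of hydrogen on an aromatic carbon of a six-membered aromatic ring of carbon only, para to a large group, gives a 1.3-fold higher number from compound 2 to compound 3 (0.11 log units; within the scatter) and is the first reading at this ring. Within the data shown here, this place therefore takes a group of 3 heavy atoms, with no ring and no hydrogen-bond donors or acceptors, without a step beyond the scatter, so the series still has no recorded step that separates two compounds. No evidence on any measured property or other outside finding bears on this result.

The compounds shown leave open whether a carboxylic acid, an amine or a longer chain at this same place would stay within the scatter of compound 2 or give a step beyond it in either direction. Also open, from the compounds shown here alone, is whether isopropyl reads the same with 2-fluorophenyl on the nitrogen in place of 4-methylphenyl, and whether an amide in place of the nitrile on the shared core would separate the numbers at all.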